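Fluorine walk on the benzyl ring of the series

The source may report more compounds than this note shows. Statements on the series, on what has been measured and on what is new or still open speak of the compounds shown alone.

Compound 1 `O=C(/C=C/c1ccc(OCc2cn(Cc3ccccc3)nn2)cc1)c1ccc(Br)cc1` is the member with an unsubstituted benzyl group. Among the measured compounds shown here, in a functional assay on MIA PaCa-2 cells (Homo sapiens) for inhibition, read by MTT assay, with a stated time of 48 h, tested at 10 uM (on this read-out higher numbers stand for more inhibition of growth at the one concentration tested and lower numbers for less inhibition of growth), compound 1 gives 44%, the highest of the three numbers measured so far. Compound 2 `O=C(/C=C/c1ccc(OCc2cn(Cc3ccccc3F)nn2)cc1)c1ccc(Br)cc1` gives 28% and compound 3 `O=C(/C=C/c1ccc(OCc2cn(Cc3cccc(F)c3)nn2)cc1)c1ccc(Br)cc1` gives 34%. The step of a number 16 percentage points lower from compound 1 to compound 2 (beyond the scatter) lies beyond the scatter, whereas the step of a number 10 percentage points lower from compound 1 to compound 3 (within the scatter) lies within it, and so does a number 6 percentage points higher from compound 2 to compound 3 (within the scatter).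

Compound 4 `O=C(/C=C/c1ccc(OCc2cn(Cc3ccc(F)cc3)nn2)cc1)c1ccc(Br)cc1` carries the change (fluoro in place of hydrogen on an aromatic carbon), sitting para to a large group. Both steps measured so far that add fluoro to this ring are the ones that bear on it. The only one of them that is beyond the scatter points downward, and the other is not distinguishable from no change. The expectation for compound 4 in this assay is therefore a small loss, at the edge of the scatter. Compound 4 is expected to give about 35%, within a range from 20% to 50%. The expected step is a number 9 percentage points lower from compound 1 to compound 4 (within the scatter).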

Compound 4, percent growth inhibition at one concentration: 32%
Estimate against measurement, compound 4: 3 percentage points above; measured number inside the range.
By their numbers in this assay, from the lowest: compounds 2, 4, 3 and 1 (each within the scatter of the next, the first and the last beyond it).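

With a number 12 percentage points lower from compound 1 to compound 4 (beyond the scatter), fluoro at this place, para to a large group, gives a loss in this assay beyond the scatter, as it does in compound 2, while compound 3 stays within the scatter of compound 1. The three fluorobenzyl compounds do not separate from one another: a number 2 percentage points lower from compound 3 to compound 4 (within the scatter) and a number 4 percentage points higher from compound 2 to compound 4 (within the scatter) both lie within the scatter, so these numbers give no ranking of the fluoro positions. Nothing available here accounts for the loss seen with fluoro.

Open, going by these compounds, is whether an amine or a carboxylic acid on this ring, in place of fluoro, would hold the number of compound 1 at 44% or move it. Also open, on these data alone, is how a longer chain in place of the benzyl group would read out.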